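Replacing the phenethyl amide of compound 2 with a dichlorophenyl amide

The compounds below may be only part of what the source reports. "The series", "measured", "known", "first", "only" and "open" are said of these compounds alone.

Three amides sharing the same core have been measured in an assay on LtK cells with ATP-sensitive inward rectifier potassium channel 11 (Homo sapiens) as the target; a lower number here means that less compound is needed, a higher number that more compound is needed for the effect. Compound 1 `O=C(Nc1c(C(O)(C(F)(F)F)C(F)(F)F)ccc2ccccc12)C1CCC1` gives 45 nM, compound 3 `O=C(Nc1c(C(O)(C(F)(F)F)C(F)(F)F)ccc2ccccc12)c1cccc([N+](=O)[O-])c1` gives 117 nM, and compound 2 `O=C(CCc1ccccc1)Nc1c(C(O)(C(F)(F)F)C(F)(F)F)ccc2ccccc12` gives 1750 nM. Compound 2 stands highest of the three, with a 39-fold higher number from compound 1 to compound 2 (1.59 log units; beyond the scatter) and, in the other direction, a 15-fold lower number from compound 2 to compound 3 (1.17 log units; beyond the scatter).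

Compound 4 `O=C(Nc1c(C(O)(C(F)(F)F)C(F)(F)F)ccc2ccccc12)c1cccc(Cl)c1Cl` has not yet been measured in this assay. It differs from compound 2 in one place: 2,3-dichlorophenyl in place of phenethyl on a carbonyl carbon.

The step from compound 2 to compound 3 bears most directly on this change, since it also exchanged phenethyl for a substituted phenyl on the carbonyl carbon and brought a large drop in the number. The step from compound 1 to compound 2 points the same way, with phenethyl on the carbonyl carbon giving by far the highest number of the set. An aryl group directly on the carbonyl is therefore expected to bring compound 4 well below compound 2, with an estimated step of a 16-fold lower number from compound 2 to compound 4 (1.20 log units; beyond the scatter). For compound 4 the estimate in this assay is 110 nM, within a range of 30 nM to 400 nM.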

Compound 4, half-maximal effective concentration: > 10000 nM
Compound 4 ended at the assay's limit (the forecaster's own chance of this, stated with the estimate: 3%); middle value at least 90-fold (1.95 log units) away from the limit.
By their numbers in this assay, from the lowest: compound 1; then compound 3; then compound 2. At a limit, above all of these: compound 4.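

Compound 4 stands at a limit of the assay, not at a number: the limit of > 10000 nM in this assay, at which 1 of the 4 values shown sits. The change gives an at least 5.7-fold higher number from compound 2 to compound 4 (0.75 log units; beyond the scatter), so an aryl group directly on the carbonyl does not by itself lower the number: compound 3 goes one way and compound 4 the other. Within the aryl amides, the outcome turns on what the ring carries, with an at least 85-fold higher number from compound 3 to compound 4 (1.93 log units; beyond the scatter), and the 2,3-dichlorophenyl amide also stands far from the cyclobutyl amide, with an at least 220-fold higher number from compound 1 to compound 4 (2.34 log units; beyond the scatter).

On these data alone, whether one chlorine alone, as in a 2-chlorophenyl or a 3-chlorophenyl amide, would have the same outcome remains open. So does where an unsubstituted phenyl on the carbonyl carbon would fall relative to these compounds.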